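Putting a Fluorobutyl Chain Back on the Ring Nitrogen

This account rests on a few compounds, and the source may have more. Where it says the series, first, only, none or still open, it means among the compounds named here.

Compound 2 `COc1ccc(F)cc1-c1cccc(-c2n[nH]c(=O)o2)c1` is the lower of the two compounds measured in a functional assay on the whole organism (strain Wistar albino) for inhibition, with Rattus norvegicus as the target, read by paw edema, with stated times of 30 min and 2 h, at a dose of 10 mg/kg by the oral route (on this read-out lower numbers stand for less inhibition and higher numbers for more inhibition at the one dose given (going by the name of the read-out)), giving 56%, while compound 1 `COc1ccc(F)cc1-c1cccc(-c2nn(CCCC#N)c(=O)o2)c1` gives 71%. Among the measured compounds shown here, the one measured step, a number 15 percentage points lower from compound 1 to compound 2 (beyond the scatter), shows a loss of inhibition when the chain on that nitrogen is taken away. Compound 3 `COc1ccc(F)cc1-c1cccc(-c2nn(CCCCF)c(=O)o2)c1` carries the change (4-fluorobutyl in place of hydrogen on an aromatic nitrogen), a chain of similar length returned to the same nitrogen. That change is expected to undo most of the earlier loss, an estimated step of a number 12 percentage points higher from compound 2 to compound 3 (beyond the scatter). Compound 3 is therefore expected to give 68%, within a range from 55% to 80%.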

Compound 3, a percentage reported as inhibition, in the whole organism at one dose (the size of the read-out at that dose, not a potency): 83%
Beside the measured number, compound 3's estimate is 15 percentage points below it; measured number above the stated range.
By their numbers in this assay, from the lowest: compound 2; then compound 1; then compound 3.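

In this assay the 4-fluorobutyl chain on the aromatic nitrogen brings a number 27 percentage points higher from compound 2 to compound 3 (beyond the scatter) and so does more than win back what hydrogen at this position gave up. The far end of the chain also counts, since fluoromethyl in place of cyano gives a number 12 percentage points higher from compound 1 to compound 3 (beyond the scatter) on an otherwise matching compound. Nothing available explains why either change moves the number this way. Still open, as far as these compounds go, is how a longer chain, or a chain ending in an amine or a carboxylic acid, would compare with 4-fluorobutyl on this nitrogen.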